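The compounds below may be only part of what the source reports. "The series", "measured", "known", "first", "only" and "open" are said of these compounds alone.

Compound 3, `COc1ccc(CNCCCNS(=O)(=O)c2cc(C(F)(F)F)cc(C(F)(F)F)c2)cc1`, is one of a small set sharing a bis(trifluoromethyl)benzenesulfonamide joined through a three-carbon chain to a benzylic amine. In a functional assay on HT-29 cells (Homo sapiens) for inhibition, read by MTT assay, with a stated time of 72 h (a higher number here means a weaker inhibitor of growth, a lower number a stronger inhibitor of growth), compound 3 gives 2900 nM. Compound 1, `COc1ccc(CNCCCNS(=O)(=O)c2cc(C(F)(F)F)cc(C(F)(F)F)c2)cc1OC`, gives 2700 nM in this assay, so the two stand together, as the step of a 1.1-fold higher number from compound 1 to compound 3 (0.03 log units; within the scatter) shows. Compound 2, `CN(CCCNS(=O)(=O)c1cc(C(F)(F)F)cc(C(F)(F)F)c1)Cc1ccccc1`, reaches only a limit of this assay, > 50000 nM. For the measured compounds named here, the step of an at least 17-fold lower number from compound 2 to compound 3 (1.23 log units; beyond the scatter) is the one large change among the measured pairs, and it sits at the limit of > 50000 nM in this assay, at which 1 of the 3 values shown sits.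

Compound 4, `O=S(=O)(NCCCNCc1ccc(Cl)cc1)c1cc(C(F)(F)F)cc(C(F)(F)F)c1`, differs from compound 3 by chloro in place of methoxy on an aromatic carbon. Going by the values given here, of the measured steps, only the one from compound 1 to compound 3 touches the same ring, and it stayed within the scatter, although it removed a methoxy rather than exchanging one for a chloro. The step from compound 2 to compound 3 alters the amine itself and does not bear on the ring substituent. On this basis compound 4 is expected to give a number close to that of compound 3, with the expected step of a 1.2-fold lower number from compound 3 to compound 4 (0.06 log units; within the scatter) lying within the scatter. The estimate for compound 4 is therefore 2500 nM, in a range from 900 nM to 7000 nM.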

Compound 4, concentration for 50% growth inhibition: 2800 nM
The estimate for compound 4 lay 1.1-fold (0.05 log units) below the measured number; low and high end bracket the measured number.
By their numbers in this assay, from the lowest: compounds 1, 4 and 3 (each within the scatter of the next). At a limit, above all of these: compound 2.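

For the compounds shown here, on the aromatic carbon para to a large group, the step of a 1.0-fold lower number from compound 3 to compound 4 (0.02 log units; within the scatter) in this assay is the first change at this position itself, since the earlier step from compound 1 to compound 3 removed the other methoxy and kept this one; chloro serves here as well as methoxy. The step of a 1.0-fold higher number from compound 1 to compound 4 (0.02 log units; within the scatter) exchanges the whole 3,4-dimethoxyphenyl for 4-chlorophenyl and also stays within the scatter, so among these compounds no methoxy on this ring is needed for a number of this size. Going by these compounds alone, the step of an at least 17-fold lower number from compound 2 to compound 4 (1.25 log units; beyond the scatter) is large, as the one to compound 3 was, and it too rests on compound 2, whose entry is a limit and not a number: the limit of > 50000 nM in this assay, at which 1 of the 4 values shown sits.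

The compounds shown do not separate the methyl on the amine of compound 2 from the bare benzyl ring it carries, so either difference could account for the large steps, and a 4-chlorobenzyl group on a methylated amine would tell them apart. From the compounds shown here alone, it also remains open whether a nitrile, a hydroxy group or a dimethylamino group at this ring position, or a longer chain, would keep the number in this range.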